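Moving the methoxy group around a phenyl ring

The source may report more compounds than this note shows. Statements on the series, on what has been measured and on what is new or still open speak of the compounds shown alone.

Measured compounds:
- compound 1, `CC(C)(C)c1cc2nn(-c3ccccc3)c(N)c2c(=O)[nH]1`: 5%
- compound 2, `Nc1c2c(=O)[nH]c(-c3ccccc3)cc2nn1-c1ccccc1`: 38%
- compound 3, `COc1ccccc1-c1cc2nn(-c3ccccc3)c(N)c2c(=O)[nH]1`: 3%

All three share one core and differ only in the group on an aromatic carbon of that core. In an assay on isolated protein for inhibition of ribosomal protein S6 kinase alpha-1 (Homo sapiens), read by mobility shift assay, tested at 30 uM (a higher number here means more inhibition at the concentration tested (going by the name of the read-out), a lower number less inhibition), compound 3 gives the lowest of the three numbers; its nearest neighbour is compound 1, which lies within the scatter of it, while compound 2 stands well above it, as the step of a number 35 percentage points lower from compound 2 to compound 3 (beyond the scatter) shows. The step of a number 2 percentage points lower from compound 1 to compound 3 (within the scatter) lies within the scatter.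

Compound 4, `COc1ccc(-c2cc3nn(-c4ccccc4)c(N)c3c(=O)[nH]2)cc1`, differs from compound 3 by 4-methoxyphenyl in place of 2-methoxyphenyl on an aromatic carbon. Among the measured compounds shown here, the only step that bears on it is a number 35 percentage points lower from compound 2 to compound 3 (beyond the scatter), which shows that adding a methoxy group to the phenyl of compound 2 at one position removed most of its inhibition. Whether a methoxy group at the other position does the same is not shown by any measured pair; compound 2 without methoxy remains the upper reference and compound 3 the lower one. A step of a number 17 percentage points higher from compound 3 to compound 4 (beyond the scatter) is therefore expected, with wide uncertainty, and compound 4 is estimated at 20%, in the range 3% to 45%.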

Compound 4, a percentage reported as inhibition, at one concentration (the size of the read-out at that concentration, not a potency): 4%
Compound 4: the middle estimate sits 16 percentage points above what was measured; low and high end bracket the measured number.
By their numbers in this assay, from the lowest: compounds 3, 4 and 1 (each within the scatter of the next); then compound 2.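

In this assay the step of a number 1 percentage points higher from compound 3 to compound 4 (within the scatter) shows that 4-methoxyphenyl and 2-methoxyphenyl cannot be told apart at this place on the core. The loss of inhibition on adding a methoxy group to the phenyl of compound 2 is thus not confined to one position of that ring, as the step of a number 34 percentage points lower from compound 2 to compound 4 (beyond the scatter) is also large. Among the compounds shown here, with the step of a number 1 percentage points lower from compound 1 to compound 4 (within the scatter) as well, 4-methoxyphenyl reads no differently from tert-butyl, leaving plain phenyl as the only group here that stands clear of the others.

As far as these compounds go, whether a group other than methoxy on that phenyl, such as an amine or a carboxylic acid, would keep the number of compound 2 stays open. Nothing at hand explains why either methoxyphenyl group sits so far under the plain phenyl.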